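This account rests on a few compounds, and the source may have more. Where it says the series, first, only, none or still open, it means among the compounds named here.

Values in a functional assay on MDA-MB-231 cells (Homo sapiens) for inhibition, read by MTT assay, with a stated time of 48 h; a lower number here means a stronger inhibitor of growth, a higher number a weaker inhibitor of growth:
- Compound 1 `CCc1cccc(Nc2ncnc3ccc(NC(=S)NCc4ccccc4)cc23)c1`: 10500 nM
- Compound 2 `CC(C)c1ccc(Nc2ncnc3ccc(NC(=S)NCc4ccccc4)cc23)cc1`: 12800 nM
- Compound 3 `Oc1cccc(Nc2ncnc3ccc(NC(=S)NCc4ccccc4)cc23)c1`: > 30000 nM

Compound 3 stands at the limit of > 30000 nM in this assay, at which 1 of the 3 values shown sits, so its entry is a limit and not a number. Compound 4 `Oc1ccc(Nc2ncnc3ccc(NC(=S)NCc4ccccc4)cc23)cc1` has 4-hydroxyphenyl in place of 3-hydroxyphenyl on a nitrogen on an aromatic ring. Two measured steps introduce the 3-hydroxyphenyl group, and both weaken growth inhibition: an at least 2.8-fold higher number from compound 1 to compound 3 (0.45 log units; beyond the scatter) and an at least 2.3-fold higher number from compound 2 to compound 3 (0.36 log units; beyond the scatter). Compound 4 keeps a hydroxy group. Among the compounds with values here, the one step that pairs a 3-substituted with a 4-substituted phenyl is a 1.2-fold higher number from compound 1 to compound 2 (0.09 log units; within the scatter). No step beyond the scatter is therefore expected, and the expected step is a number no higher from compound 3 to compound 4 (the limit leaves the size open). Compound 4 is estimated at 30000 nM, with an expected range of 14000 nM to 60000 nM.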

Compound 4, concentration for 50% growth inhibition: 27000 nM
Compound 4: the middle estimate sits 1.1-fold (0.05 log units) above what was measured; the measured number falls inside the stated range.
By their numbers in this assay, from the lowest: compounds 1 and 2 (each within the scatter of the next); then compound 4. At a limit, above all of these: compound 3.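

In this assay, compound 4 gives a hydroxy compound with a number rather than a limit, so the loss against the alkyl-substituted compounds can now be sized: a 2.1-fold higher number from compound 2 to compound 4 (0.32 log units; beyond the scatter) and a 2.6-fold higher number from compound 1 to compound 4 (0.41 log units; beyond the scatter). Compound 3 stands at a limit and not a number: the limit of > 30000 nM in this assay, at which 1 of the 4 values shown sits. As far as these compounds go, the change from 3-hydroxyphenyl to 4-hydroxyphenyl reads only as an at least 1.1-fold lower number from compound 3 to compound 4 (0.04 log units; that floor lies within the scatter), so its true size stays unknown.

The compounds shown leave open how 4-aminophenyl or 4-methoxyphenyl in the same place would compare with compound 2 and compound 4.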